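A few compounds are considered here, and "the series" means these few. Any claim that something is new, unique, unknown or untested is made for them only; others in the source may bear on it.

Three compounds have been measured in a functional assay (trachea) with Cavia porcellus as the target; a lower number here means a stronger inhibitor, a higher number a weaker inhibitor:

Compound 1 `CCCCn1nc(-c2cccnc2)c2ccccc2c1=O` gives 2290 nM.
Compound 2 `CCCCCCCCn1nc(-c2cccnc2)c2ccccc2c1=O` gives 21900 nM.
Compound 3 `O=c1c2ccccc2c(-c2cccnc2)nn1C1CCCC1` gives 2750 nM.

Compound 2 stands highest of the three: a 9.6-fold higher number from compound 1 to compound 2 (0.98 log units; beyond the scatter) and an 8.0-fold lower number from compound 2 to compound 3 (0.90 log units; beyond the scatter) both lie beyond the scatter, while a 1.2-fold higher number from compound 1 to compound 3 (0.08 log units; within the scatter). Compound 4 `O=c1c2ccccc2c(-c2cccnc2)nn1CCSc1nccs1` differs from compound 2 in one place: (1,3-thiazol-2-yl)sulfanyl in place of hexyl on a saturated chain carbon, two bonds along the chain from an aromatic nitrogen. The two steps that bear on this both start from compound 2, and both show that a shorter plain chain on the aromatic nitrogen brings a markedly lower number. The incoming group likewise shortens the plain chain, though its ring and acceptors have no precedent among these compounds, so the expected step is a 7.3-fold lower number from compound 2 to compound 4 (0.86 log units; beyond the scatter). Compound 4 is therefore estimated at 3000 nM, within a range from 800 nM to 12000 nM.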

Compound 4, half-maximal inhibitory concentration: 10500 nM
Compound 4: the middle estimate sits 3.5-fold (0.54 log units) below what was measured; measured number inside the range.
By their numbers in this assay, from the lowest: compounds 1 and 3 (each within the scatter of the next); then compound 4; then compound 2.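

Exchanging hexyl for (1,3-thiazol-2-yl)sulfanyl, two groups with the same heavy-atom count, changes the number only modestly (a 2.1-fold lower number from compound 2 to compound 4 (0.32 log units; beyond the scatter)). The position therefore accepts a chain carrying a five-membered aromatic ring, but compound 4 remains weaker than the butyl and cyclopentyl compounds (a 3.8-fold higher number from compound 3 to compound 4 (0.58 log units; beyond the scatter); a 4.6-fold higher number from compound 1 to compound 4 (0.66 log units; beyond the scatter)). No supporting measurement accounts for this placing.

As far as these compounds go, whether an amine or a carboxylic acid at the end of the chain would give a lower number remains open. So does the effect of replacing the sulfur with oxygen.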